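The source may report more compounds than this note shows. Statements on the series, on what has been measured and on what is new or still open speak of the compounds shown alone.

The measured compounds:
compound 1, `CC(C)c1ccc(-c2nc(SCc3cn(CC(=O)NC(=O)Nc4ccccn4)nn3)nc(Nc3ccc(F)cc3)c2C#N)cc1`: > 64000 nM
compound 2, `CC(C)c1ccc(-c2nc(SCc3cn(CC(=O)NC(=O)Nc4ccccn4)nn3)nc(Nc3ccccc3F)c2C#N)cc1`: > 64000 nM

In a functional assay on MCF7 cells (Homo sapiens) for inhibition, read by MTT assay, with a stated time of 72 h (on this read-out higher numbers stand for weaker inhibition and lower numbers for stronger inhibition), compound 1 gives > 64000 nM, which is a limit of the assay and not a number. In this assay compound 2 gives > 64000 nM, again a limit and not a number. The step that the two limits leave unreadable from compound 1 to compound 2 is therefore unreadable, and compound 2 stands only at the limit of > 64000 nM in this assay, at which 2 of the 2 values shown sit, without a numerical value of its own. Compound 3, `COc1ccccc1Nc1nc(SCc2cn(CC(=O)NC(=O)Nc3ccccn3)nn2)nc(-c2ccc(C(C)C)cc2)c1C#N`, is the next member of the series. It differs from compound 2 by methoxy in place of fluoro on an aromatic carbon. No measured step bears on a methoxy group; the only step shown, from 4-fluorophenyl to 2-fluorophenyl on the nitrogen, is unreadable because both of its ends sit at the limit of > 64000 nM in this assay, at which 2 of the 2 values shown sit. There is thus no basis for expecting a readable step in this assay in one direction or the other. Compound 3 is expected to give 64000 nM in this assay, with a range of 20000 nM to 200000 nM. The step of a number no higher from compound 2 to compound 3 (the limit leaves the size open) is expected to stay within the scatter. Most likely the assay will again report only a limit for compound 3.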

Compound 3, half-maximal inhibitory concentration: 19300 nM
Beside the measured number, compound 3's estimate is 3.3-fold (0.52 log units) above it; the whole stated range lies above it.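

In this assay, going by these compounds alone, methoxy in place of fluoro on the aromatic carbon, ortho to a large group, gives an at least 3.3-fold lower number from compound 2 to compound 3 (0.52 log units; beyond the scatter), the first readable step. Measured against the other fluorinated compound, 2-methoxyphenyl in place of 4-fluorophenyl on the nitrogen gives an at least 3.3-fold lower number from compound 1 to compound 3 (0.52 log units; beyond the scatter), so this position can carry a change that brings a compound off the limit, although both steps give only a lower bound on their size. The step between the two fluorinated compounds still cannot be read, and compound 3 alone has a number of its own, the others remaining limits and not numbers: the limit of > 64000 nM in this assay, at which 2 of the 3 values shown sit.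

The compounds shown leave open whether a hydroxy, ethoxy or methyl group on this same aromatic carbon would also give a readable number, or whether the step is particular to methoxy. They also leave open whether methoxy placed elsewhere on this ring would do the same, and whether a stronger compound could be reached from compound 3 by changing the parts of the molecule that all three share.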